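The source may report more compounds than this note shows. Statements on the series, on what has been measured and on what is new or still open speak of the compounds shown alone.

Compound 1 `COc1cc(/C=C/C(=O)c2ccccc2F)cc(OC)c1OC` is tested in a functional assay on A549 cells (Homo sapiens) for cytotoxicity, read by MTT assay, with a stated time of 72 h; on this read-out lower numbers stand for stronger inhibition and higher numbers for weaker inhibition. In this assay compound 1 gives only a limit, > 100000 nM, which is the limit of > 100000 nM in this assay, at which 1 of the 3 values shown sits. Compound 2 `COc1cc(/C=C/C(=O)c2ccccc2F)cc(OC)c1` differs from compound 1 by hydrogen in place of methoxy on an aromatic carbon, and in this assay compound 2 gives 43.6 nM; the step is an at least 2200-fold lower number from compound 1 to compound 2 (3.36 log units; beyond the scatter). Compound 3 `COc1ccc(C(=O)/C=C/c2ccc(OC)c(OC)c2OC)c(F)c1` gives 108 nM in this assay; the difference between the core of compound 3 and the core of compound 1 is not broken down here. Compound 4 `COc1ccc(C(=O)/C=C/c2ccc(OC)cc2OC)c(F)c1` differs from compound 3 by hydrogen in place of methoxy on an aromatic carbon, the same kind of change as that from compound 1 to compound 2, although here the altered carbon is meta rather than para to a large group. Resting on compound 1 and the step of an at least 2200-fold lower number from compound 1 to compound 2 (3.36 log units; beyond the scatter), the step from compound 3 to compound 4 is expected to be a 2.7-fold lower number from compound 3 to compound 4 (0.43 log units; beyond the scatter), with a smaller size likely because the starting point of compound 3, 108 nM, is already low. Compound 4 is therefore estimated at 40 nM, between 8 nM and 300 nM.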

Compound 4, half-maximal inhibitory concentration: > 100000 nM
Compound 4 was reported as a limit; the forecaster's own chance of this, stated with the estimate: 5%; middle value at least 2500-fold (3.39 log units) from the limit.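

In this assay hydrogen in place of methoxy gave an at least 920-fold higher number from compound 3 to compound 4 (2.96 log units; beyond the scatter) and so did not carry over from one core to the other, since the direction of the step reversed: the same change on two cores in this assay, an at least 2200-fold lower number (3.36 log units; beyond the scatter) from compound 1 to compound 2 and an at least 920-fold higher number (2.96 log units; beyond the scatter) from compound 3 to compound 4, at least 2100000-fold (6.32 log units) apart, beyond the scatter of two such steps. From the compounds shown here alone, compound 1 and compound 4 each stand at a limit of the assay rather than at a number, so the full size of each step stays unknown: the limit of > 100000 nM in this assay, at which 2 of the 4 values shown sit. These two pairs show that the outcome of this change depends on the core, but not which difference between the cores decides it, and they give no rule for any other core.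

The compounds shown leave open how a hydroxyl, a chlorine or an amine in place of that methoxy would fare on either core.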